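The source may report more compounds than this note shows. Statements on the series, on what has been measured and on what is new or still open speak of the compounds shown alone.

Compound 1 `CCCCNc1nc(N)nc2ccc(OC)cc12` gives 1.8 uM in an ADME assay on HEK293 cells for agonist activity at Toll-like receptor 8 (Homo sapiens), read by a luciferase reporter, with a stated time of 6 h; on this read-out higher numbers stand for an effect only at larger amounts of compound and lower numbers for an effect already at smaller amounts.
Compound 2 `CCCCNc1nc(N)nc2ccc(CO)cc12` gives 0.2 uM in this assay.

Going by the values given here, compound 2 stands lowest of the two numbers measured so far. Among the compounds with values here, the only step known, a 9.0-fold lower number from compound 1 to compound 2 (0.95 log units; beyond the scatter), changes the group on the same aromatic carbon that is changed again here. Compound 3 `CCCCNc1nc(N)nc2ccc(C(C)=O)cc12` differs from compound 2 by acetyl in place of hydroxymethyl on an aromatic carbon. Within the data shown here, that earlier step shows this position can move the read-out, but no measured compound carries an acetyl, so only a small step is expected, a 2.0-fold higher number from compound 2 to compound 3 (0.30 log units; within the scatter), and its direction is uncertain. Compound 3 is therefore estimated at 0.4 uM, with a range from 0.1 uM to 1.8 uM.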

Compound 3, minimum effective concentration: 1.9 uM
Beside the measured number, compound 3's estimate is 4.8-fold (0.68 log units) below it; the whole stated range lies below it.
By their numbers in this assay, from the lowest: compound 2; then compounds 1 and 3 (each within the scatter of the next).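

Swapping hydroxymethyl for acetyl is not a small change on this aromatic carbon: this assay shows a 9.5-fold higher number from compound 2 to compound 3 (0.98 log units; beyond the scatter). Acetyl and methoxy cannot be told apart here, with a 1.1-fold higher number from compound 1 to compound 3 (0.02 log units; within the scatter), so among these three groups only hydroxymethyl stands apart, and the low number of compound 2 belongs to that group alone. Nothing available explains why hydroxymethyl differs from the other two. From the compounds shown here alone, whether an amine, a carboxylic acid or a longer chain such as hydroxyethyl on this carbon would match compound 2 remains open.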